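Swapping a Chlorinated Ring for a Longer Chain

The source may hold more compounds than are shown below. What is called first, only, known or untested is meant among the compounds shown, and "the series" means these compounds.

Of the compounds shown here, two have so far been measured in an assay on isolated protein for binding affinity to Equilibrative nucleoside transporter 1 (Homo sapiens); a lower number here means a stronger inhibitor, a higher number a weaker inhibitor. Compound 1, `OC[C@H]1O[C@@H](n2cnc3c(SCCCc4ccccc4)ncnc32)[C@H](O)[C@@H]1O`, gives 1350 nM. Compound 2, `Nc1nc(SCc2ccccc2Cl)c2ncn([C@@H]3O[C@H](CO)[C@@H](O)[C@H]3O)c2n1`, gives 13500 nM, the higher of the two numbers; its nearest neighbour is compound 1, whose number is lower by a gap that lies beyond the usual scatter.

Compound 3, `Nc1nc(SCCc2ccccc2)c2ncn([C@@H]3O[C@H](CO)[C@@H](O)[C@H]3O)c2n1`, has not yet been measured. It differs from compound 2 in one place: benzyl in place of 2-chlorophenyl on a saturated chain carbon bound to a sulfur. Among the measured compounds shown here, no pair of measured compounds differs in exactly this way, so the size of this step cannot be read directly from the data. For the measured compounds named here, the only guide is compound 1, which also carries a chain ending in an unsubstituted phenyl ring on its sulfur and gives 1350 nM, a clearly lower number than compound 2. On that basis the step of a 2.3-fold lower number from compound 2 to compound 3 (0.35 log units; beyond the scatter) is expected to move toward a lower number, by an amount somewhat beyond the scatter. Compound 3 is therefore estimated at about 6000 nM, with a plausible range from 2000 nM to 20000 nM.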

Compound 3, half-maximal inhibitory concentration: 16200 nM
Estimate against measurement, compound 3: 2.7-fold (0.43 log units) below; the range from low to high includes it.
By their numbers in this assay, from the lowest: compound 1; then compounds 2 and 3 (each within the scatter of the next).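

In this assay, the step of a 1.2-fold higher number from compound 2 to compound 3 (0.08 log units; within the scatter) lies within the usual scatter, so this assay does not tell the two compounds apart. On a saturated chain carbon bound to a sulfur, the 2-chlorophenyl and benzyl groups each count 7 heavy atoms and one six-membered aromatic ring of carbon only, and exchanging them, which turns 2-chlorobenzyl into phenethyl, leaves no change that can be read from these numbers. The data shown offer no measured explanation for this result.

This single exchange removes the chlorine and lengthens the chain in one move, so the two changes could have effects that offset each other or could each have almost no effect, and the pair cannot separate these possibilities. A 2-chlorophenethyl group, which keeps the chlorine on the longer chain, and a plain benzyl group on the sulfur, which drops the chlorine from the shorter chain, would each isolate one of the two changes, while a longer 3-phenylpropyl chain on this same core would show whether further lengthening matters.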